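Deoxyribonucleoside analogues as weak thymidine kinase inhibitors

The compounds below may be only part of what the source reports. "The series", "measured", "known", "first", "only" and "open" are said of these compounds alone.

Measured so far in an assay on BHK21 (C13) cells (Mesocricetus auratus) for inhibition of thymidine kinase, cytosolic (Cricetulus griseus), using Lineweaver-Burk analysis; on this read-out lower numbers stand for stronger inhibition and higher numbers for weaker inhibition:
compound 1 `Nc1cn([C@H]2C[C@H](O)[C@@H](CO)O2)c(=O)[nH]c1=O` gives 450000 nM
compound 2 `CC(=O)NCCNC[C@H]1O[C@@H](n2cc(C)c(=O)[nH]c2=O)C[C@@H]1O` gives 250000 nM
compound 3 `CC(=O)N(C)CCN(C)C[C@H]1O[C@@H](n2cc(C)c(=O)[nH]c2=O)C[C@@H]1O` gives 900000 nM

Compound 2 has the lowest of the three numbers. The nearest to it is compound 1, whose value lies within the scatter of repeated measurements, so no order between compound 2 and compound 1 can be read from these two values. Compound 3 stands furthest away, beyond the scatter, and thus gives weaker inhibition than compound 2 in this assay.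

Compound 4 `Cc1cn([C@H]2C[C@H](O)[C@@H](CSCCCC(=O)O)O2)c(=O)[nH]c1=O` has not yet been measured. It differs from compound 2 in one place: (3-carboxypropyl)sulfanyl in place of (2-acetamidoethyl)amino on a saturated chain carbon bound to a saturated ring carbon. Going by the values given here, no step between measured compounds covers a change of this kind, so no size can be taken from the set. All three measured numbers sit in a narrow band of weak inhibition, and the leaving and entering groups are counted as equal in heavy atoms. A step from compound 2 to compound 4 is therefore expected to stay within the scatter, or at most to be a small move towards a higher number. Compound 4 is expected to give 350000 nM in this assay, with a range from 90000 nM to 1400000 nM. This estimate means a step of a 1.4-fold higher number from compound 2 to compound 4 (0.15 log units; within the scatter), expected to lie within the scatter.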

Compound 4, inhibition constant: 1200000 nM
Beside the measured number, compound 4's estimate is 3.4-fold (0.54 log units) below it, within the range that was stated.
By their numbers in this assay, from the lowest: compounds 2, 1, 3 and 4 (each within the scatter of the next, the first and the last beyond it).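

At the saturated chain carbon bound to a saturated ring carbon, the two side chains are not interchangeable in this assay: although the leaving and entering groups have equal heavy-atom counts, (3-carboxypropyl)sulfanyl in place of (2-acetamidoethyl)amino gives a 4.8-fold higher number from compound 2 to compound 4 (0.68 log units; beyond the scatter) on this read-out. Going by these compounds alone, this is the first single-place step, and it shows that this position can register a change beyond the scatter, even among such weak inhibitors. No measurement on hand accounts for this step.

The change replaces the linking atom and the chain end together, so the compounds shown leave open which of the two carries the step. A sulfanyl chain ending in a methyl ester, or an amino-linked chain ending in a carboxylic acid, would separate the two.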